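Trimethoxyphenyl swap in the benzylidene series

The source may report more compounds than this note shows. Statements on the series, on what has been measured and on what is new or still open speak of the compounds shown alone.

Measured so far in a functional assay on BGC-823 cells (Homo sapiens) for inhibition, read by MTT assay, with a stated time of 72 h; on this read-out lower numbers stand for stronger inhibition and higher numbers for weaker inhibition:
compound 1 `O=C1/C(=C\c2ccccc2)c2c(ncn2COCc2ccccc2)CCN1Cc1ccc(F)cc1` gives 72900 nM
compound 2 `COc1cc(/C=C2\C(=O)N(Cc3ccccc3)CCc3ncn(COCc4ccccc4)c32)cc(OC)c1OC` gives 12900 nM

Compound 2 at 12900 nM has the lower number of the two, so it shows the stronger inhibition, and its gap to compound 1 lies beyond the usual scatter. The next compound to be measured is compound 3 `O=C1/C(=C\c2ccc(C(F)(F)F)cc2)c2c(ncn2COCc2ccccc2)CCN1Cc1ccccc1`, which differs from compound 2 by one change, (4-(trifluoromethyl)phenyl in place of 3,4,5-trimethoxyphenyl on a double-bonded chain carbon bound to a double-bonded ring carbon), on a double-bonded chain carbon bound to a double-bonded ring carbon.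

Going by the values given here, no two measured compounds differ in only one place, so this change has no direct precedent. Among the compounds with values here, the only guide is compound 1 at 72900 nM, which also lacks the 3,4,5-trimethoxyphenyl but differs from compound 2 elsewhere as well, which makes it weak evidence. A moderate move toward weaker inhibition is expected in this assay, with an estimated 2.3-fold higher number from compound 2 to compound 3 (0.37 log units; beyond the scatter) as the result. The estimate for compound 3 is 30000 nM, with the measurement expected to fall from 10000 nM to 90000 nM in this series.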

Compound 3, half-maximal inhibitory concentration: 42600 nM
Compound 3: the middle estimate sits 1.4-fold (0.15 log units) below what was measured; the measured number falls inside the stated range.
By their numbers in this assay, from the lowest: compound 2; then compounds 3 and 1 (each within the scatter of the next).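

In this assay, going by these compounds alone, replacing 3,4,5-trimethoxyphenyl with 4-(trifluoromethyl)phenyl on a double-bonded chain carbon bound to a double-bonded ring carbon gives a 3.3-fold higher number from compound 2 to compound 3 (0.52 log units; beyond the scatter) and so provides the first one-place comparison. This shows that the group at this position affects the read-out, and that this swap weakens inhibition by a modest step. The leaving group has 12 heavy atoms and 3 hydrogen-bond acceptors, against 10 heavy atoms and 0 hydrogen-bond acceptors for the entering group, but a single step cannot show which of these differences, if any, matters. No supporting data link the step to a measured property of either group.

Among the compounds shown, compound 1 has no partner that differs from it in one place, so its changes cannot be read separately. On these data alone, it remains open whether a phenyl ring with a single methoxy group would keep the lower number of compound 2, and whether a dimethylamino group or a carboxylic acid on that ring would move the number in either direction.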